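A chloro added to an inactive sulfone

A few compounds are considered here, and "the series" means these few. Any claim that something is new, unique, unknown or untested is made for them only; others in the source may bear on it.

Compound 1 `O=S(=O)(CC1=NCCS1)C1=NNCC1c1ccccc1` was tested in a functional assay, tested at 100 ug/mL (on this read-out lower numbers stand for a weaker effect and higher numbers for a stronger effect at the one concentration tested), and gave "not active" (no number reported), so no number stands for it. Two related compounds are known in this assay: compound 2 `O=S(=O)(CC1=NCCO1)c1n[nH]cc1-c1ccccc1` gives 58.5%, and compound 3 `O=S(=O)(CC1=NCCO1)c1c(-c2ccccc2)nn(-c2ccccc2)c1-c1ccccc1` gives 59.1%. Among the measured compounds shown here, no step between measured compounds is available to calibrate the change considered here.

Compound 4 `O=S(=O)(CC1=NCCS1)C1=NNCC1c1ccc(Cl)cc1` differs from compound 1 in one place: chloro in place of hydrogen on an aromatic carbon. With compound 1 reported as inactive, the step in this assay is expected to be small, with at most a modest rise that may not exceed the scatter. Compound 4 is therefore estimated to show 12% in this assay, within a range from 0% to 35%, and it may again be reported as not active.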

Compound 4, a percentage reported as activity, at one concentration (the size of the read-out at that concentration, not a potency): "not active" (no number reported)
Compound 4 has no reported number here; there is nothing to compare the estimate with.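

In this assay compound 1 gives "not active" (no number reported) and compound 4 gives "not active" (no number reported), so no step can be read between them. The compounds shown leave open whether the chloro changes this read-out at all, and no measurement shown bears on the result.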